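Hydroxyethyl Replaces the Aryl Group on the Triazole Chain

The source may report more compounds than this note shows. Statements on the series, on what has been measured and on what is new or still open speak of the compounds shown alone.

Compound 3 `COc1ccc([C@@H]2CC(=O)c3c(O)cc(OCc4cn(Cc5ccc(C(F)(F)F)cc5)nn4)cc3O2)cc1O` was tested in a functional assay on RAW264.7 cells (Mus musculus) for inhibition, read by Griess assay, with stated times of 2 h and 24 h (on this read-out higher numbers stand for weaker inhibition and lower numbers for stronger inhibition), and gave 17700 nM. Going by the values given here, that is the highest of the three numbers measured so far. Its nearest neighbour is compound 2 `COc1ccc([C@@H]2CC(=O)c3c(O)cc(OCc4cn(Cc5ccc(F)cc5)nn4)cc3O2)cc1O`, which in this assay gives 15100 nM; the step of a 1.2-fold higher number from compound 2 to compound 3 (0.07 log units; within the scatter) stays within the scatter. The furthest is compound 1 `COc1ccc([C@@H]2CC(=O)c3c(O)cc(OCc4cn(Cc5ccccc5F)nn4)cc3O2)cc1O`, which in this assay gives 7320 nM; here the step of a 2.4-fold higher number from compound 1 to compound 3 (0.38 log units; beyond the scatter) lies beyond the scatter.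

Compound 4 `COc1ccc([C@@H]2CC(=O)c3c(O)cc(OCc4cn(CCCO)nn4)cc3O2)cc1O` has not yet been measured. It differs from compound 3 in one place: 2-hydroxyethyl in place of 4-(trifluoromethyl)phenyl on a saturated chain carbon bound to an aromatic nitrogen. The measured steps that touch this place are a 2.4-fold higher number from compound 1 to compound 3 (0.38 log units; beyond the scatter) and a 1.2-fold higher number from compound 2 to compound 3 (0.07 log units; within the scatter), one modest and one within the scatter, and both exchange one aryl group for another. Among the compounds with values here, no measured pair exchanges an aryl group for a short chain carrying a hydrogen-bond donor and acceptor, so the data give no firm direction for this change. For compound 4 in this assay a step of a 1.2-fold lower number from compound 3 to compound 4 (0.07 log units; within the scatter) is expected, which means no step beyond the scatter, but with wide uncertainty. Compound 4 is therefore estimated at 15000 nM, in a range from 5000 nM to 45000 nM.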

Compound 4, half-maximal inhibitory concentration: 16700 nM
Beside the measured number, compound 4's estimate is 1.1-fold (0.05 log units) below it, and the stated range covers the measured number.
By their numbers in this assay, from the lowest: compound 1; then compounds 2, 4 and 3 (each within the scatter of the next).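

The aromatic ring itself turns out not to be required at this position in this assay: exchanging it for 2-hydroxyethyl, with no ring and 3 heavy atoms, gives a 1.1-fold lower number from compound 3 to compound 4 (0.03 log units; within the scatter) and a 1.1-fold higher number from compound 2 to compound 4 (0.04 log units; within the scatter), so a group with 1 hydrogen-bond donor and 1 hydrogen-bond acceptor sits level with both para-free-named aryl groups, 4-(trifluoromethyl)phenyl and 4-fluorophenyl. Only 2-fluorophenyl stands apart, with a 2.3-fold higher number from compound 1 to compound 4 (0.36 log units; beyond the scatter), which shows that the lower number of compound 1 does not come with an aryl group as such, since compound 2 and compound 3 carry aryl groups and do not share it. Nothing measured here explains why these groups behave as they do.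

What the compounds shown leave open is whether an amine, a carboxylic acid or a longer chain ending in a hydroxyl group at this place would stay level with compound 4 or move away from it. They also leave open whether 2-chlorophenyl or 2-methoxyphenyl would match compound 1, or whether its number belongs to 2-fluorophenyl alone.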